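The compounds below may be only part of what the source reports. "The series", "measured", "known", "first", "only" and "open" are said of these compounds alone.

Compound 1 `O=C(O)CC/C=C\CC1COC(c2ccc(C(F)(F)F)cc2)OC1c1cccnc1`: an assay for inhibition of Thromboxane-A synthase (Homo sapiens), using microsomes (on this read-out higher numbers stand for weaker inhibition and lower numbers for stronger inhibition), 44 nM
Compound 2 `O=C(O)CC/C=C\CC1COC(c2cccs2)OC1c1cccnc1`: 71 nM
Compound 3 `CC(C)(Oc1ccccc1)C1OCC(C/C=C\CCC(=O)O)C(c2cccnc2)O1`: 52 nM

Compound 3 stands second highest of the three numbers, but both steps leading to it, a 1.2-fold higher number from compound 1 to compound 3 (0.07 log units; within the scatter) and a 1.4-fold lower number from compound 2 to compound 3 (0.14 log units; within the scatter), lie within the scatter, as does a 1.6-fold higher number from compound 1 to compound 2 (0.21 log units; within the scatter); the three compounds are indistinguishable on this read-out.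

Compound 4 `Cc1ccc(OC(C)(C)C2OCC(C/C=C\CCC(=O)O)C(c3cccnc3)O2)cc1` differs from compound 3 by methyl in place of hydrogen on an aromatic carbon. Going by the values given here, no measured step touches this kind of change: all three exchange the whole group on the saturated ring carbon, and none of them moves the number beyond the scatter. With wholesale swaps there leaving the read-out flat, a single methyl added on the aromatic ring is expected to give no step beyond the scatter, a 1.0-fold lower number from compound 3 to compound 4 (0.02 log units; within the scatter). Compound 4 is therefore estimated at 50 nM in this assay, within a range of 25 nM to 100 nM.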

Compound 4, half-maximal inhibitory concentration: 360 nM
Compound 4: middle estimate off by 7.2-fold (0.86 log units), on the low side, outside the stated range (above it).
By their numbers in this assay, from the lowest: compounds 1, 3 and 2 (each within the scatter of the next); then compound 4.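

Going by these compounds alone, in this read-out, this assay, methyl in place of hydrogen on an aromatic carbon, para to a large group, gives a 6.9-fold higher number from compound 3 to compound 4 (0.84 log units; beyond the scatter) as the first step beyond the scatter. Wholesale exchanges on the saturated ring carbon left the number flat, yet this single added carbon moves it, so this position on the phenoxy ring is not indifferent to substitution. Nothing at hand accounts for the step.

Open, as far as these compounds go, is whether the step belongs to methyl alone: chlorine, methoxy or hydroxyl on the same carbon would test that. Also open, from the compounds shown here alone, is whether methyl on another carbon of this ring behaves alike.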